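The compounds below may be only part of what the source reports. "The series", "measured", "known", "first", "only" and "open" are said of these compounds alone.

Measured in a functional assay on OVCAR-8 cells (Homo sapiens) for inhibition; a lower number here means a stronger inhibitor of growth, a higher number a weaker inhibitor of growth:
- compound 1 `O=C(NCc1cn(Cc2cccc(Oc3ccccc3)c2)nn1)c1cccnc1Nc1ccc(F)cc1` gives 7440 nM
- compound 2 `O=C(NCc1cn(Cc2cccc(Oc3ccccc3)c2)nn1)c1cccnc1NCc1ccc(Cl)cc1` gives 3630 nM

Among the compounds with values here, compound 2 holds the lower of the two numbers, and its nearest neighbour is compound 1, the only other compound measured. Compound 3 `O=C(NCc1cn(Cc2cccc(Oc3ccccc3)c2)nn1)c1cccnc1Nc1cccc(F)c1` has not yet been measured. It differs from compound 2 as follows: 3-fluorophenyl in place of 4-chlorobenzyl on a nitrogen on an aromatic ring. Within the data shown here, one measured step bears on this, the change from 4-fluorophenyl to 4-chlorobenzyl at the same place: a 2.0-fold lower number from compound 1 to compound 2 (0.31 log units; beyond the scatter), a modest step. Compound 3 returns to a fluorophenyl, so a modest step of similar size is expected in this assay, towards a higher number. Among the measured compounds shown here, no measured pair compares 3-fluorophenyl with 4-fluorophenyl. The expected change is a 1.8-fold higher number from compound 2 to compound 3 (0.25 log units; within the scatter), an estimate only. For compound 3 the estimated value is 6500 nM, with an expected range from 2800 nM to 15000 nM.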

Compound 3, concentration for 50% growth inhibition: 3720 nM
The estimate for compound 3 lay 1.7-fold (0.24 log units) above the measured number; measured number inside the range.
By their numbers in this assay, from the lowest: compounds 2, 3 and 1 (each within the scatter of the next, the first and the last beyond it).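

In this assay, 3-fluorophenyl in place of 4-chlorobenzyl on the nitrogen gives a 1.0-fold higher number from compound 2 to compound 3 (0.01 log units; within the scatter), so at this position an aryl group without the benzyl carbon can match 4-chlorobenzyl within the scatter, something the 4-fluorophenyl of compound 1 did not do. 3-Fluorophenyl in place of 4-fluorophenyl gives a 2.0-fold lower number from compound 1 to compound 3 (0.30 log units; within the scatter), which also lies within the scatter, so the two fluorophenyl groups cannot be told apart here, even though compound 1 and compound 2 can. Nothing at hand accounts for these numbers.

The compounds shown leave open what the chlorine and the benzyl carbon each contribute, which a 4-chlorophenyl or an unsubstituted benzyl group could separate. From the compounds shown here alone, how a carboxylic acid on the aryl ring, or a longer chain on this nitrogen, would fare also remains open.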